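A Cyclic Amine in Place of the Amide Carbonyl

The source may report more compounds than this note shows. Statements on the series, on what has been measured and on what is new or still open speak of the compounds shown alone.

Compound 1 `Cc1ccc(C2CCN(S(=O)(=O)c3c(C)cc(C)cc3C)CC2)cc1`: 2200 nM
Compound 2 `Cc1cc(C)c(S(=O)(=O)N2CCC(C(=O)N3CCC(C)CC3)CC2)c(C)c1`: > 5000 nM

In a functional assay on DLD-1 cells (Homo sapiens) for antiproliferative activity, read by CellTiter-Glo, with a stated time of 72 h (a higher number here means a weaker inhibitor, a lower number a stronger inhibitor), compound 1 gives 2200 nM. Compound 2 reaches only the limit of > 5000 nM in this assay, so no number is known for it. Within the data shown here, the single measured step, an at least 2.2-fold higher number from compound 1 to compound 2 (0.35 log units; beyond the scatter), sits at the same saturated ring carbon, and the limit of > 5000 nM in this assay, at which 1 of the 2 values shown sits, is where compound 2 stands. Among the measured compounds shown here, compound 3 `Cc1cc(C)c(S(=O)(=O)N2CCC(N3CCC(C)OC3)CC2)c(C)c1` differs from compound 2 by a group of 7 heavy atoms (5 carbon, 1 nitrogen, 1 oxygen; one six-membered non-aromatic ring with 2 hetero atoms) in place of a group of 9 heavy atoms (7 carbon, 1 nitrogen, 1 oxygen; one six-membered non-aromatic ring with 1 hetero atom), on a saturated ring carbon, a change no measured pair mirrors, so no clear direction is indicated. Compound 3 is expected to give about 5000 nM, from 2000 nM to 15000 nM. The expected step is a number no higher from compound 2 to compound 3 (the limit leaves the size open), and a further limit is likely.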

Compound 3, half-maximal inhibitory concentration: 92 nM
For compound 3 the middle estimate is 54-fold (1.74 log units) above the measured one; the measured number lies below the stated range.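

At this saturated ring carbon, the group with two hetero atoms in its ring stands out in this assay, whereas the earlier change there had only weakened the number: the steps are an at least 54-fold lower number from compound 2 to compound 3 (1.73 log units; beyond the scatter) and a 24-fold lower number from compound 1 to compound 3 (1.38 log units; beyond the scatter). The value of compound 2, > 5000 nM, is a limit. Nothing shown accounts for this gain.

The compounds shown leave open whether the ring oxygen and the ring methyl are both needed. They also leave open whether a piperazine or an open-chain amine on this carbon would do as well.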